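The source may report more compounds than this note shows. Statements on the series, on what has been measured and on what is new or still open speak of the compounds shown alone.

Values so far in a physicochemical assay for lipophilicity, measured as octanol-water partition; a higher number here means a more lipophilic compound, a lower number a more polar compound

Compound 1 `CC(=O)N[C@H](C(=O)N1C[C@H](O)C[C@H]1C(=O)N[C@@H](CCC(C)(C)C)c1ccc(-c2scnc2C)cc1)C(C)(C)C` gives 3.21
Compound 2 `CC(=O)N[C@H](C(=O)N1C[C@H](O)C[C@H]1C(=O)N[C@@H](CCc1ccc(Br)cc1)c1ccc(-c2scnc2C)cc1)C(C)(C)C` gives 4.08
Compound 3 `CC(=O)N[C@H](C(=O)N1C[C@H](O)C[C@H]1C(=O)N[C@@H](CCc1ccc(O)cc1)c1ccc(-c2scnc2C)cc1)C(C)(C)C` gives 3.08

Two steps fix where compound 3 stands: a number 0.13 log units lower from compound 1 to compound 3 (within the scatter) and a number 1.00 log units lower from compound 2 to compound 3 (beyond the scatter) leave it level with one neighbour and clearly under the other. Compound 4 `CC(=O)N[C@H](C(=O)N1C[C@H](O)C[C@H]1C(=O)N[C@@H](CCc1ccncc1)c1ccc(-c2scnc2C)cc1)C(C)(C)C` carries pyridin-4-yl in place of 4-hydroxyphenyl on the same saturated chain carbon (pyridin-4-yl in place of 4-hydroxyphenyl on a saturated chain carbon, three bonds along the chain from an amide-type nitrogen and an aromatic carbon). Going by the values given here, no measured step makes this exact swap. The nearest guide is the change on the aromatic ring, a number 1.00 log units lower from compound 2 to compound 3 (beyond the scatter) as its size, so a move of modest size seems plausible. A modest fall in this assay is expected, and the estimated step is a number 0.38 log units lower from compound 3 to compound 4 (beyond the scatter) with its direction only tentative. The estimate for compound 4 is 2.7 (expected range 2.2 to 3.2), still awaiting measurement.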

Compound 4, partition coefficient: 2.18
The estimate for compound 4 lay 0.52 log units above the measured number; the whole stated range lies above it.
By their numbers in this assay, from the lowest: compound 4; then compounds 3 and 1 (each within the scatter of the next); then compound 2.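

In this assay, pyridin-4-yl gives the lowest number of the set: a number 0.90 log units lower from compound 3 to compound 4 (beyond the scatter), a number 1.03 log units lower from compound 1 to compound 4 (beyond the scatter) and a number 1.90 log units lower from compound 2 to compound 4 (beyond the scatter). Compound 3 had stayed level with compound 1, so only now does a ring at this saturated chain carbon fall clearly under tert-butyl. Nothing available here accounts for the size of this fall. Going by these compounds, what a pyridin-3-yl or a 4-aminophenyl group would give at this place remains open, so it is unknown whether the fall is specific to pyridin-4-yl.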